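Trimming the Amide Substituent of Compound 2

The source may report more compounds than this note shows. Statements on the series, on what has been measured and on what is new or still open speak of the compounds shown alone.

Going by the values given here, compound 2 `COc1cc(-c2nn(-c3cccc(NC(=O)Nc4cccc(C(F)(F)F)c4)c3)cc2-c2ccncc2)ccc1Cl` gives 1940 nM in a functional assay on RXF 393 cells (Homo sapiens) for inhibition, read by sulforhodamine B assay, with a stated time of 48 h (on this read-out higher numbers stand for weaker inhibition of growth and lower numbers for stronger inhibition of growth), the lowest of the two numbers known; compound 1 `O=C(Nc1cccc(-n2cc(-c3ccncc3)c(-c3ccc(Cl)c(O)c3)n2)c1)Nc1cccc(C(F)(F)F)c1` gives 12000 nM, and the step of a 6.2-fold lower number from compound 1 to compound 2 (0.79 log units; beyond the scatter) separates them. Compound 3 `COc1cc(-c2nn(-c3cccc(NC(=O)c4ccccc4)c3)cc2-c2ccncc2)ccc1Cl` differs from compound 2 by phenyl in place of (3-(trifluoromethyl)phenyl)amino on a carbonyl carbon. Among the compounds with values here, no measured step touches this carbonyl carbon, since the only known step concerns the methyl on the oxygen, so the expectation rests on the change itself, which removes a group carrying one hydrogen-bond donor. Compound 3 is therefore expected to give 6000 nM, with a range of 1500 nM to 25000 nM. The estimated step of a 3.1-fold higher number from compound 2 to compound 3 (0.49 log units; beyond the scatter) is expected to be a weakening beyond the scatter.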

Compound 3, concentration for total growth inhibition: 6340 nM
For compound 3 the middle estimate is 1.1-fold (0.02 log units) below the measured one, and the stated range covers the measured number.
By their numbers in this assay, from the lowest: compound 2; then compounds 3 and 1 (each within the scatter of the next).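

At the carbonyl carbon, phenyl in place of (3-(trifluoromethyl)phenyl)amino gives a 3.3-fold higher number from compound 2 to compound 3 (0.51 log units; beyond the scatter) in this assay, so this position, untouched by the earlier step on the oxygen, also affects the read-out. The change removes the amino nitrogen and the trifluoromethyl together, so the step cannot be assigned to either alone. Nothing available explains the weakening. The compounds shown leave open whether phenylamino without the trifluoromethyl on this carbonyl carbon would match compound 2, and what a morpholine or a carboxylic acid on that phenyl would do.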